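This account rests on a few compounds, and the source may have more. Where it says the series, first, only, none or still open, it means among the compounds named here.

The measured compounds: compound 1, `COc1cc(Nc2nc(C)cc(N(C)C)n2)ccc1F`, gives > 250000 nM in a physicochemical assay for solubility, read by nephelometry, measured as kinetic solubility (a higher number here means a more soluble compound, a lower number a less soluble compound), which is a limit of the assay and not a number. Compound 2, `COc1cc(Nc2nc(C)cc(N3CCCCC3)n2)ccc1F`, gives 160000 nM in this assay. Compound 3, `COc1cc(Nc2nc(C)cc(N3CCCC3)n2)ccc1F`, gives 220000 nM in this assay.

Compound 2 holds the lowest of the two numbers, and its gap to compound 3, a 1.4-fold higher number from compound 2 to compound 3 (0.14 log units; within the scatter), lies within the scatter. Compound 4, `CCOC1CCCN(c2cc(C)nc(Nc3ccc(F)c(OC)c3)n2)C1`, differs from compound 2 by ethoxy in place of hydrogen on a saturated ring carbon. For the measured compounds named here, none of the measured steps touches a saturated ring carbon; the steps of an at least 1.5-fold lower number from compound 1 to compound 2 (0.19 log units; that floor lies within the scatter) and an at least 1.1-fold lower number from compound 1 to compound 3 (0.05 log units; that floor lies within the scatter) exchange the whole amine and are themselves within the scatter. No step beyond the scatter is therefore expected in this assay. The expected step is a 1.1-fold lower number from compound 2 to compound 4 (0.03 log units; within the scatter). Compound 4 is thus estimated at 150000 nM, with a range from 60000 nM to 300000 nM.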

Compound 4, solubility: > 250000 nM
Compound 4: a limit, no number; the forecaster's own chance of this, stated with the estimate: 20%; middle value at least 1.6-fold (0.22 log units) from the limit.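

In this assay compound 4 gives > 250000 nM as a limit of the assay and not a number. Ethoxy in place of hydrogen on a saturated ring carbon, the first change shown at this position, gives an at least 1.5-fold higher number from compound 2 to compound 4 (0.19 log units; that floor lies within the scatter) and so brings no lower number. The full size of this step cannot be read because the value of compound 4 is a limit: the limit of > 250000 nM in this assay, at which 2 of the 4 values shown sit. As far as these compounds go, whether an amine, a carboxylic acid or a longer chain on this ring carbon would also reach this limit stays open.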